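A few compounds are considered here, and "the series" means these few. Any claim that something is new, unique, unknown or untested is made for them only; others in the source may bear on it.

In an ADME assay on WI-38 cells (Homo sapiens) for cytotoxicity, read by MTT assay, with a stated time of 72 h (a higher number here means a weaker inhibitor, a lower number a stronger inhibitor), compound 1 (`O=C(CCc1cccc2c1B(O)OC2)Nc1ccccc1`) gives 30000 nM. Compound 2 (`O=C(CCc1cccc2c1B(O)OC2)Nc1ccc(Br)cc1`) gives 42000 nM, with bromo in place of hydrogen giving a 1.4-fold higher number from compound 1 to compound 2 (0.15 log units; within the scatter). Compound 3 (`Cc1ccc(NC(=O)CCc2cccc3c2B(O)OC3)cc1`) gives > 100000 nM, which is a limit and not a number. Methyl in place of hydrogen gave an at least 3.3-fold higher number from compound 1 to compound 3 (0.52 log units; beyond the scatter), and methyl in place of bromo gave an at least 2.3-fold higher number from compound 2 to compound 3 (0.37 log units; beyond the scatter). Compound 4 (`COc1ccc(NC(=O)CCc2cccc3c2B(O)OC3)cc1`) carries methoxy in place of methyl on an aromatic carbon, para to a large group: methoxy in place of methyl on an aromatic carbon. For the measured compounds named here, no measured step involves methoxy, so these three steps only frame the expectation in this assay: a modest move to a lower number, or none beyond the scatter. The step expected is an at least 1.5-fold lower number from compound 3 to compound 4 (0.18 log units; that floor lies within the scatter). The estimate for compound 4 is 65000 nM, with an expected range from 25000 nM to 150000 nM.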

Compound 4, half-maximal inhibitory concentration: > 100000 nM
Compound 4: a limit, no number; the forecaster's own chance of this, stated with the estimate: 35%; middle value at least 1.5-fold (0.18 log units) from the limit.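

In this assay compound 4 gives > 100000 nM, a limit and not a number, so methoxy, like methyl, leaves this position without a measured value. Methoxy in place of hydrogen gives an at least 3.3-fold higher number from compound 1 to compound 4 (0.52 log units; beyond the scatter), and methoxy in place of bromo gives an at least 2.3-fold higher number from compound 2 to compound 4 (0.37 log units; beyond the scatter). The step between compound 3 and compound 4 cannot be read, and methyl and methoxy cannot be ordered, because both sit at the same limit: the limit of > 100000 nM in this assay, at which 2 of the 4 values shown sit.

As far as these compounds go, whether an amine or a carboxylic acid at this position would also reach the limit stays open. From the compounds shown here alone, the true values of compound 3 and compound 4 also stay open.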